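Swapping a Carboxyphenyl for a Dimethoxyphenyl

The source may report more compounds than this note shows. Statements on the series, on what has been measured and on what is new or still open speak of the compounds shown alone.

Measured so far:
Compound 1 `C=C1[C@@H](OC(C)=O)C[C@@H]2[C@](C)(CO[Si](C)(C)C(C)(C)C)[C@H](OC(C)=O)CC[C@@]2(C)[C@@H]1C[C@@H](Nc1ccc(C(=O)O)cc1)C1=CCOC1=O`: 4210 nM
Compound 2 `C=C1[C@@H](OC(C)=O)C[C@@H]2[C@](C)(CO[Si](C)(C)C(C)(C)C)[C@H](OC(C)=O)CC[C@@]2(C)[C@@H]1C[C@@H](Nc1ccccc1C(=O)O)C1=CCOC1=O`: 4890 nM

Both compounds share one core and differ only in the aryl group attached to the amine nitrogen. In a functional assay on A549 cells (Homo sapiens) for cytotoxicity, read by sulforhodamine B assay (a lower number here means a stronger inhibitor, a higher number a weaker inhibitor), compound 1 gives 4210 nM, and compound 2 gives 4890 nM. The step of a 1.2-fold higher number from compound 1 to compound 2 (0.07 log units; within the scatter), so the two readings cannot be told apart: compound 2 stands beside compound 1 rather than apart from it, and neither can be called the stronger inhibitor.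

Compound 3 `C=C1[C@@H](OC(C)=O)C[C@@H]2[C@](C)(CO[Si](C)(C)C(C)(C)C)[C@H](OC(C)=O)CC[C@@]2(C)[C@@H]1C[C@@H](Nc1ccc(OC)c(OC)c1)C1=CCOC1=O` carries the change (3,4-dimethoxyphenyl in place of 2-carboxyphenyl on an amine nitrogen). Among the compounds with values here, no measured step trades the carboxylic acid for methoxy groups; the only step known, a 1.2-fold higher number from compound 1 to compound 2 (0.07 log units; within the scatter), moved the acid to another position on the ring and left this assay unchanged. Nothing measured therefore points clearly in either direction, and the expected step is a 1.4-fold lower number from compound 2 to compound 3 (0.15 log units; within the scatter), small and uncertain, with a wide range allowed on both sides. Compound 3 is estimated at 3500 nM, with a likely range from 1200 nM to 10000 nM.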

Compound 3, half-maximal inhibitory concentration: 4870 nM
Beside the measured number, compound 3's estimate is 1.4-fold (0.14 log units) below it; low and high end bracket the measured number.
By their numbers in this assay, from the lowest: compounds 1, 3 and 2 (each within the scatter of the next).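

Compound 3 is the first compound shown without a carboxylic acid: the group on the amine nitrogen goes from 1 hydrogen-bond donor and 1 acceptor to 0 donors and 2 acceptors, yet this assay gives a 1.0-fold lower number from compound 2 to compound 3 (0.00 log units; within the scatter) and also a 1.2-fold higher number from compound 1 to compound 3 (0.06 log units; within the scatter) within this series. Earlier, the acid had only changed its place on the ring, so the new result adds something different: among these compounds, the acid can be replaced entirely by two methoxy groups with no change that can be told from scatter. No supporting measurement explains why the three readings sit so close together.

As far as these compounds go, all three compounds keep a substituted phenyl ring on the nitrogen, so it remains open whether this position responds to anything in this assay, and a plain alkyl chain in place of the ring, or an amine on the ring, would test that. From the compounds shown here alone, whether a group at this position can push the number clearly lower or higher than these readings also remains open.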